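The source may hold more compounds than are shown below. What is called first, only, known or untested is meant among the compounds shown, and "the series" means these compounds.

Measured compounds in the series:

compound 1, `CN(C)CC1CCCc2cc(S(=O)(=O)c3ccccc3)ccc21`: 0.0631 nM
compound 2, `Cn1ccc(S(=O)(=O)c2ccc3c(c2)CCC[C@H]3CN)c1`: 7.94 nM
compound 3, `CN(CC(N)=O)C[C@@H]1CCCc2cc(S(=O)(=O)c3cccc(F)c3)ccc21`: 1.26 nM

All three numbers come from an assay on isolated protein for displacement of a labelled ligand from 5-hydroxytryptamine receptor 6 (Homo sapiens); a lower number here means a stronger inhibitor, a higher number a weaker inhibitor. Among them compound 3 holds the second-highest number: compound 1 lies below it by a gap beyond the scatter, and compound 2 lies above it, also by a gap beyond the scatter. Compound 3 thus sits between the two, closer to compound 2 than to compound 1.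

The next compound, compound 4, `CC(C)(C)C(=O)NC[C@@H]1CCCc2cc(S(=O)(=O)c3cccc(F)c3)ccc21`, has not been measured in this assay. Its structure differs from that of compound 3 in one place: ((tert-butyl)carbonyl)amino in place of (carbamoylmethyl)(methyl)amino on a saturated chain carbon bound to a saturated ring carbon. The change exchanges one hydrogen-bond acceptor for none and removes a nitrogen from the chain while adding carbons to it.

Within the data shown here, no measured pair shows this exact exchange, so the size of the step can only be guessed. The expectation is a move toward a higher number, beyond the scatter, with a step of a 25-fold higher number from compound 3 to compound 4 (1.40 log units; beyond the scatter) from compound 3 to compound 4. On that basis compound 4 is estimated to give 32 nM in this assay, within a range from 5 nM to 250 nM.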

Compound 4, inhibition constant: 3.98 nM
Estimate against measurement, compound 4: 8.0-fold (0.91 log units) above; the measured number lies below the stated range.
By their numbers in this assay, from the lowest: compound 1; then compound 3; then compounds 4 and 2 (each within the scatter of the next).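

In this assay, ((tert-butyl)carbonyl)amino in place of (carbamoylmethyl)(methyl)amino on a saturated chain carbon bound to a saturated ring carbon gives a 3.2-fold higher number from compound 3 to compound 4 (0.50 log units; beyond the scatter), a modest step beyond the scatter. Among these compounds, this is the first single-place reading at this position, and it shows that the group of 7 heavy atoms, with 1 hydrogen-bond acceptor against 2 in the group it replaces, costs only this much. The exchange alters several counted features at once, and no measurement here links the step to any one of them or to a cause.

As far as these compounds go, what a carboxylic acid in this place would give, with the rest of compound 4 kept, remains open. From the compounds shown here alone, it is also open whether the same exchange gives a step of similar size with a different group on the sulfonyl.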